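A Methyl Added to the Core of Compound 1

The source may hold more compounds than are shown below. What is called first, only, known or untested is meant among the compounds shown, and "the series" means these compounds.

Compound 1 `Cc1cc(S(=O)(=O)/N=C(\N)n2nccc2-c2ccccc2)c(SCc2ccc(Cl)cc2)cc1Cl` is one of three related compounds tested in a functional assay on HCT-116 cells (Homo sapiens) for cytotoxicity, read by MTT assay, with a stated time of 72 h; a lower number here means a stronger inhibitor, a higher number a weaker inhibitor. Compound 1 gives 7000 nM. Compound 2 `Cc1cc(S(=O)(=O)/N=C(\N)n2nccc2-c2ccccc2)c(SCc2cccc(Cl)c2)cc1Cl` gives 7000 nM, and compound 3 `Cc1cc(S(=O)(=O)/N=C(\N)n2nccc2-c2ccccc2)c(SCc2cccc(C(F)(F)F)c2)cc1Cl` gives 14000 nM. Compound 1 and compound 2 stand level, together the lowest of the three numbers, and the step of a 2.0-fold higher number from compound 1 to compound 3 (0.30 log units; within the scatter) stays within the scatter.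

Compound 4 `Cc1cc(-c2ccccc2)n(/C(N)=N/S(=O)(=O)c2cc(C)c(Cl)cc2SCc2ccc(Cl)cc2)n1` differs from compound 1 by methyl in place of hydrogen on an aromatic carbon. The measured steps all alter the group on the saturated chain carbon bound to a sulfur or a substituent on its aromatic ring: no change at the digits printed from compound 1 to compound 2 (within the scatter), a 2.0-fold higher number from compound 1 to compound 3 (0.30 log units; within the scatter), and a 2.0-fold higher number from compound 2 to compound 3 (0.30 log units; within the scatter), each within the scatter. Among the compounds with values here, none of them alters the five-membered aromatic ring with 2 nitrogen, so they give no direct guide; they show only that small changes have so far stayed within the scatter. Compound 4 is therefore expected to show no change at the digits printed from compound 1 to compound 4 (within the scatter), that is, no step beyond the scatter. Compound 4 is estimated at 7000 nM, within a range from 3000 nM to 16000 nM.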

Compound 4, half-maximal inhibitory concentration: 7000 nM
Beside the measured number, compound 4's estimate shows no gap at the digits printed, within the range that was stated.
By their numbers in this assay, from the lowest: compounds 1, 2, 4 and 3 (each within the scatter of the next).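

Methyl in place of hydrogen on an aromatic carbon of the five-membered aromatic ring with 2 nitrogen gives no change at the digits printed from compound 1 to compound 4 (within the scatter) in this assay. Within the data shown here, this is the first measured change on that ring, as the earlier steps all altered the group on the saturated chain carbon bound to a sulfur, and it shows that this position can carry one added carbon without a step beyond the scatter. No measurement is available that would explain this result.

From the compounds shown here alone, whether a longer chain such as propyl, an amine or a carboxylic acid at this position would also stay within the scatter remains open. Also open, going by these compounds, is whether the methyl would give the same result when combined with the 3-chlorophenyl group of compound 2 or the 3-(trifluoromethyl)phenyl group of compound 3.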